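Series notes: substituted phenyl at the saturated ring carbon

The compounds below may be only part of what the source reports. "The series", "measured", "known", "first", "only" and "open" are said of these compounds alone.

In a functional assay on MCF7 cells (Homo sapiens) for antiproliferative activity, read by MTT assay, with a stated time of 48 h (a lower number here means a stronger inhibitor, a higher number a weaker inhibitor), compound 1 `CC(=O)N1N=C(c2ccc3ccccc3c2)OC1c1ccccc1` gives 2.43 ug/mL, compound 2 `CC(=O)N1N=C(c2ccc3ccccc3c2)OC1c1cccc(Br)c1` gives 2.34 ug/mL, and compound 3 `CC(=O)N1N=C(c2ccc3ccccc3c2)OC1c1ccccc1Cl` gives 2.36 ug/mL. Compound 2 stands level with both neighbours: the steps of a 1.0-fold lower number from compound 1 to compound 2 (0.02 log units; within the scatter) and a 1.0-fold higher number from compound 2 to compound 3 (0.00 log units; within the scatter) are within the scatter, as is a 1.0-fold lower number from compound 1 to compound 3 (0.01 log units; within the scatter). Compound 4 `CC(=O)N1N=C(c2ccc3ccccc3c2)OC1c1ccc([N+](=O)[O-])cc1` is unmeasured; its change from compound 2 is 4-nitrophenyl in place of 3-bromophenyl on a saturated ring carbon. The three measured steps all bear on this change, since each swaps one group on the same saturated ring carbon, and none moved this assay beyond the scatter. No step beyond the scatter is therefore expected in this assay for compound 4, which is estimated at 2.4 ug/mL (range 1.2 ug/mL to 4.8 ug/mL), a step of a 1.0-fold higher number from compound 2 to compound 4 (0.01 log units; within the scatter) from compound 2.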

Compound 4, half-maximal inhibitory concentration: 7.59 ug/mL
Estimate against measurement, compound 4: 3.2-fold (0.50 log units) below; the whole stated range lies below it.
By their numbers in this assay, from the lowest: compounds 2, 3 and 1 (each within the scatter of the next); then compound 4.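

At the saturated ring carbon, the phenyl substituent can matter in this assay: 4-nitrophenyl gives a 3.2-fold higher number from compound 2 to compound 4 (0.51 log units; beyond the scatter), a 3.2-fold higher number from compound 3 to compound 4 (0.51 log units; beyond the scatter) and a 3.1-fold higher number from compound 1 to compound 4 (0.49 log units; beyond the scatter). Phenyl, 3-bromophenyl and 2-chlorophenyl stayed level, so this position is not indifferent to every change on the phenyl, and a higher number is the only direction seen here. No measurement shown bears on the reason for this step.

Compound 4 alone carries a group at its place on the phenyl, leaving the nitro group and its placement inseparable. An amine or a carboxylic acid on the phenyl remains an open case.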